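This account rests on a few compounds, and the source may have more. Where it says the series, first, only, none or still open, it means among the compounds named here.

Values in a functional assay on MCF7 cells (Homo sapiens) for inhibition; on this read-out lower numbers stand for stronger inhibition and higher numbers for weaker inhibition:
- compound 1 `CCCCCCCC[C@@]1(C)SC(O)=C(C)C1=O`: 16.5 ug/mL
- compound 2 `CCCCCC[C@@]1(C)SC(=O)C=C1OCCCCCl`: 8.6 ug/mL
- compound 3 `CCCCCCCC[C@@]1(C)SC(O)=C(C(C)O)C1=O`: 17.6 ug/mL; 21.7 ug/mL (2 entries)

Compound 1 has one close neighbour with a single number, compound 2. The values of these two lie within the scatter of each other, so no order can be read between them. Compound 3 has two entries rather than one number, and these show how far repeats can differ: the several entries of compound 3 in this assay, 17.6 ug/mL; 21.7 ug/mL (2 entries). Both of its entries also lie within the scatter of the value of compound 1.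

Compound 4 `CCCCCCCC[C@@]1(C)SC(O)=C(C(C)=O)C1=O` has not yet been measured. It differs from compound 1 by acetyl in place of methyl on a double-bonded ring carbon.

Going by the values given here, no measured step between two compounds covers this change, so the expectation for this assay rests on the values alone. Compound 1 at 16.5 ug/mL and compound 3 at 17.6 ug/mL; 21.7 ug/mL (2 entries) lie close together, and no shift beyond the scatter is expected in either direction. The expected step of a 1.1-fold higher number from compound 1 to compound 4 (0.04 log units; within the scatter) stays within the scatter. For compound 4 the estimated value is 18 ug/mL, with an expected range from 8 ug/mL to 40 ug/mL.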

Compound 4, half-maximal inhibitory concentration: 12 ug/mL
For compound 4 the middle estimate is 1.5-fold (0.18 log units) above the measured one, within the range that was stated.
By their numbers in this assay, from the lowest: compounds 2, 4 and 1 (each within the scatter of the next).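

Acetyl in place of methyl on a double-bonded ring carbon gives the only step that can be read at this position in this assay: a 1.4-fold lower number from compound 1 to compound 4 (0.14 log units; within the scatter). The position therefore accepts a group with two more carbons and one more oxygen, including a hydrogen-bond acceptor and a double bond outside the ring, without a shift beyond the scatter, so the number for compound 4 stays in the same range as the number for compound 1. No order can be read from a step of this size, and the entries of a single compound in this assay also differ from one another: the several entries of compound 3 in this assay, 17.6 ug/mL; 21.7 ug/mL (2 entries)

From the compounds shown here alone, it remains open whether a group of another kind on this double-bonded ring carbon, such as an amine or a carboxylic acid, would move the number beyond the scatter. Going by these compounds, it is equally open whether a longer chain in place of the group of 8 heavy atoms on the ring would alter the picture, alone or together with the acetyl group.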